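Replacing a methoxyphenyl arm with a fluorophenyl arm

The source may report more compounds than this note shows. Statements on the series, on what has been measured and on what is new or still open speak of the compounds shown alone.

Of the compounds shown here, three built on one shared core have been measured in a functional assay on MCF7 cells (Homo sapiens) for cytotoxicity, with a stated time of 48 h; on this read-out lower numbers stand for stronger inhibition and higher numbers for weaker inhibition. Compound 1 `COc1ccc(-c2cc(COC(Cc3cn(C4CCN(Cc5ccc([N+](=O)[O-])cc5)CC4)nn3)c3ccc(Br)cc3)on2)cc1` gives 4000 nM, compound 2 `N#Cc1ccc(-c2cc(COC(Cc3cn(C4CCN(Cc5ccc([N+](=O)[O-])cc5)CC4)nn3)c3ccc(Br)cc3)on2)cc1` gives 3000 nM, and compound 3 `COc1cccc(-c2cc(COC(Cc3cn(C4CCN(Cc5ccc([N+](=O)[O-])cc5)CC4)nn3)c3ccc(Br)cc3)on2)c1` gives 7000 nM. Compound 3 thus carries the highest of the three numbers, as the two steps that lead up to it show: a 1.8-fold higher number from compound 1 to compound 3 (0.24 log units; within the scatter), and a 2.3-fold higher number from compound 2 to compound 3 (0.37 log units; beyond the scatter).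

Compound 4 `O=[N+]([O-])c1ccc(CN2CCC(n3cc(CC(OCc4cc(-c5ccccc5F)no4)c4ccc(Br)cc4)nn3)CC2)cc1` differs from compound 3 in one place: 2-fluorophenyl in place of 3-methoxyphenyl on an aromatic carbon. Within the data shown here, no measured step exchanges a methoxyphenyl for a fluorophenyl directly. Among the measured compounds shown here, the steps that bear on it are a 1.8-fold higher number from compound 1 to compound 3 (0.24 log units; within the scatter), which moved the methoxy group from one ring carbon to another, and a 1.3-fold lower number from compound 1 to compound 2 (0.12 log units; within the scatter), which swapped the methoxy group for a cyano group. Both changes at this position left the number essentially where it was. A step of that modest size, or none beyond the scatter, is therefore expected in this assay, leaning slightly toward a lower number because compound 3 already gives the highest value at 7000 nM.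

Compound 4 is expected to give about 5000 nM in this assay, with a range from 2000 nM to 14000 nM. That estimate corresponds to an expected step of a 1.4-fold lower number from compound 3 to compound 4 (0.15 log units; within the scatter).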

Compound 4, half-maximal inhibitory concentration: 8000 nM
The estimate for compound 4 lay 1.6-fold (0.20 log units) below the measured number, and the stated range covers the measured number.
By their numbers in this assay, from the lowest: compounds 2, 1, 3 and 4 (each within the scatter of the next, the first and the last beyond it).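

In this assay, 2-fluorophenyl in place of 3-methoxyphenyl gives a 1.1-fold higher number from compound 3 to compound 4 (0.06 log units; within the scatter) and so leaves the read-out unmoved, which shows that this aromatic carbon, next to the ring nitrogen, tolerates an arm with a fluorine and no oxygen. Set against the other two arms, the same 2-fluorophenyl group gives a 2.0-fold higher number from compound 1 to compound 4 (0.30 log units; within the scatter) for the 4-methoxyphenyl arm, which also stays within the usual variation, and a 2.7-fold higher number from compound 2 to compound 4 (0.43 log units; beyond the scatter) for the 4-cyanophenyl arm, the largest step in the series, though still modest. The 4-cyanophenyl arm of compound 2 is thus the only one that separates from any other at this position, and it does so from compound 3 and compound 4 but not from compound 1; no other data accompany these numbers that could account for this.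

On these data alone, all four arms are substituted phenyl groups, so it remains open how this position would respond to an amine, a carboxylic acid or a longer alkyl chain. As far as these compounds go, whether the flat response holds on other cell lines, or with different groups elsewhere on the shared core, also remains open.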